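The compounds below may be only part of what the source reports. "The series", "measured", "known", "first", "only" and "open" are said of these compounds alone.

Of the compounds shown here, three with a shared core have been measured so far. In an ADME assay on BHK cells (Mesocricetus auratus) for cytotoxicity, read by MTT assay, with a stated time of 96 h (on this read-out higher numbers stand for lower toxicity in this test and lower numbers for higher toxicity in this test), compound 1 `FC(F)(F)c1cccc(NC(=S)Nc2ccc(I)cc2)c1` gives 9400 nM, compound 2 `FC(F)(F)c1cccc(NC(=S)Nc2ccc(Cl)cc2)c1` gives 10000 nM and compound 3 `Fc1ccc(NC(=S)Nc2cccc(C(F)(F)F)c2)cc1Cl` gives 10000 nM. Compound 3 thus stands level with compound 2, and all three values lie within the scatter of one another. Compound 4 `Fc1ccc(NC(=S)Nc2cccc(C(F)(F)F)c2)cc1` differs from compound 3 by one change: hydrogen in place of chloro on an aromatic carbon. Within the data shown here, the one measured step that bears on this is a 1.1-fold higher number from compound 1 to compound 2 (0.03 log units; within the scatter), an exchange of iodo for chloro. Among the measured compounds shown here, no measured pair shows chloro giving way to hydrogen, so this is only indirect evidence, and no step beyond the scatter is expected in this assay. The expected step is a 1.1-fold higher number from compound 3 to compound 4 (0.04 log units; within the scatter). Compound 4 is estimated at 11000 nM, within an expected range of 5000 nM to 30000 nM.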

Compound 4, half-maximal cytotoxic concentration: 26000 nM
The estimate for compound 4 lay 2.4-fold (0.37 log units) below the measured number; low and high end bracket the measured number.
By their numbers in this assay, from the lowest: compounds 1, 2 and 3 (each within the scatter of the next); then compound 4.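

In this assay, among these compounds, the loss of the chloro group ortho to a fluoro group gives a 2.6-fold higher number from compound 3 to compound 4 (0.41 log units; beyond the scatter) and is the first change to go beyond the scatter. Fluoro in place of chloro gives a 2.6-fold higher number from compound 2 to compound 4 (0.41 log units; beyond the scatter) and fluoro in place of iodo gives a 2.8-fold higher number from compound 1 to compound 4 (0.44 log units; beyond the scatter), so only compound 4, with neither chloro nor iodo, stands apart from the others. No measurement shown here explains this shift. The compounds shown leave open how a methoxy group or an amine on that aromatic carbon would read in this test.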